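The compounds below may be only part of what the source reports. "The series", "measured", "known", "first", "only" and "open" are said of these compounds alone.

In a functional assay on A549 cells (Homo sapiens) for cytotoxicity, read by MTT assay, with a stated time of 48 h (a lower number here means a stronger inhibitor, a higher number a weaker inhibitor), compound 1 (`CCOC(=O)[C@@]1(C(=O)NCc2ccc(C)cc2)C[C@H]1c1cc(OC)c(OC)c(OC)c1`) gives 17100 nM. Compound 2 (`CCOC(=O)[C@]1(C(=O)NCc2ccc(C)cc2)C[C@H]1c1cc(OC)c(OC)c(OC)c1`) gives 13300 nM, which is a 1.3-fold lower number from compound 1 to compound 2 (0.11 log units; within the scatter). This pair comes with the fact that compounds 1 and 2 differ only in the configuration as drawn. Compound 3 (`COc1cc([C@@H]2C[C@@]2(CO)C(=O)NCc2ccc(C)cc2)cc(OC)c1OC`) gives 46300 nM, which is a 2.7-fold higher number from compound 1 to compound 3 (0.43 log units; beyond the scatter), and here hydroxymethyl stands in place of ethoxycarbonyl on a saturated ring carbon. Compound 1 therefore stands with compound 2 and apart from compound 3.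

The next compound changes a different part of the molecule. Compound 4 (`CCOC(=O)[C@@]1(C(=O)Nc2ccccc2Cl)C[C@H]1c1cc(OC)c(OC)c(OC)c1`) keeps the core of compound 1, but has 2-chlorophenyl in place of 4-methylbenzyl on an amide-type nitrogen. Neither measured step touches this place, so both bear on the question only indirectly. They show the size of change seen so far in this small set: a shift within the scatter for compound 2 and a modest one for compound 3. Nothing measured here points to a direction for the new change, so the expectation stays close to compound 1, with a wide margin on both sides. The estimated change is a 1.1-fold lower number from compound 1 to compound 4 (0.06 log units; within the scatter), which would not be expected to lie clearly beyond the scatter. For compound 4 the estimated value is 15000 nM, with an expected range from 6000 nM to 40000 nM.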

Compound 4, half-maximal inhibitory concentration: 17600 nM
For compound 4 the middle estimate is 1.2-fold (0.07 log units) below the measured one; the range from low to high includes it.
By their numbers in this assay, from the lowest: compounds 2, 1 and 4 (each within the scatter of the next); then compound 3.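

In this assay, the exchange on the amide-type nitrogen gives a 1.0-fold higher number from compound 1 to compound 4 (0.01 log units; within the scatter), so at this place 4-methylbenzyl and 2-chlorophenyl cannot be told apart. This exchange alters the group in more than one way, since a chlorine enters and the benzyl group gives way to a phenyl ring, yet the number stays within the scatter, whereas the change on the saturated ring carbon gives a 2.7-fold higher number from compound 1 to compound 3 (0.43 log units; beyond the scatter). Nothing known here explains why these two groups give matching numbers.

The two groups shown at this place both carry a six-membered aromatic ring of carbon only, so it remains open whether a group without such a ring, such as a plain butyl chain, or one bearing an amine or a carboxylic acid, would leave the number equally unmoved. Going by these compounds, it also remains open whether 2-chlorophenyl would match 4-methylbenzyl in the same way with hydroxymethyl in place of ethoxycarbonyl, as in compound 3, or with the configuration drawn in compound 2.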